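From 1H-imidazol-2-yl to 1,3,5-trimethyl-1H-pyrazol-4-yl: lipophilicity

The compounds below may be only part of what the source reports. "The series", "measured", "known", "first", "only" and "open" are said of these compounds alone.

Measured so far:
- compound 1, `Cc1cc(Cl)c(-c2ncc[nH]2)cc1NC(=O)c1ccc(OCc2ccccn2)cc1`: > 3
- compound 2, `Cc1ccc(-c2cnc(C)n2C)cc1NC(=O)c1ccc(OCc2ccccn2)cc1`: 2.8
- compound 3, `Cc1cc(C)c(-c2ncc[nH]2)cc1NC(=O)c1ccc(OCc2ccccn2)cc1`: 3.1

Three compounds share one core and differ only in the small ring attached to it and its neighbours. In a physicochemical assay for lipophilicity (a higher number here means a more lipophilic compound, a lower number a more polar compound), compound 1 reaches > 3, which is a limit of the assay and not a number. Compound 2 gives 2.8 in this assay, and compound 3 gives 3.1; these two numbers lie within the scatter of one another, so no order between them can be read. For the measured compounds named here, the only pair that differs in one place is compound 1 and compound 3, and that step, a step that the limit leaves unreadable from compound 1 to compound 3, cannot be sized because of the limit of > 3 in this assay, at which 1 of the 3 values shown sits.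

Compound 4, `Cc1cc(C)c(-c2c(C)nn(C)c2C)cc1NC(=O)c1ccc(OCc2ccccn2)cc1`, has not yet been measured. It differs from compound 3 in one place: 1,3,5-trimethyl-1H-pyrazol-4-yl in place of 1H-imidazol-2-yl on an aromatic carbon. Going by the values given here, no measured step covers this exchange, so the expectation rests on the change itself rather than on a recorded step. The value of compound 4 in this assay is estimated at 3.7, expected to fall between 3.2 and 4.2. The estimated step of a number 0.60 log units higher from compound 3 to compound 4 (beyond the scatter) is expected to be upward and beyond the scatter.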

Compound 4, distribution coefficient: > 3
Compound 4 gave a limit, no number; the forecaster's own chance of this, stated with the estimate: 30%; the middle value is on the limit's open side.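

In this assay compound 4 gives > 3, which is a limit of the assay and not a number. No new step can be read between compound 3 and compound 4, because of this: the limit of > 3 in this assay, at which 2 of the 4 values shown sit.

The compounds shown leave open how large the exchange of 1H-imidazol-2-yl for 1,3,5-trimethyl-1H-pyrazol-4-yl is in this read-out.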